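A few compounds are considered here, and "the series" means these few. Any claim that something is new, unique, unknown or untested is made for them only; others in the source may bear on it.

Measured compounds:
Compound 1 `COc1cc2c(Oc3ccc(NC(=O)c4nn(-c5cccc(F)c5)c(=O)cc4C)cc3F)ccnc2cc1OCCCN1CCCC1` — 280 nM
Compound 2 `COc1cc2c(Oc3ccc(NC(=O)c4nn(-c5cccc(F)c5)c(=O)cc4C)cc3F)ccnc2cc1OCCCN1CCN(C)CC1` — 260 nM

In a functional assay on NCI-H460 cells (Homo sapiens) for inhibition, read by MTT assay, with a stated time of 72 h (on this read-out lower numbers stand for stronger inhibition and higher numbers for weaker inhibition), compound 1 gives 280 nM and compound 2 gives 260 nM. Among the compounds with values here, compound 2 sits at the low end of these two numbers, but the only measured step, a 1.1-fold lower number from compound 1 to compound 2 (0.03 log units; within the scatter), lies within the usual scatter, so the two compounds cannot be told apart on this read-out. That step concerns the amine at the end of the chain, and it shows that swapping one such amine for another leaves the number essentially unchanged.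

Compound 3 `COc1cc2c(Oc3ccc(NC(=O)c4nn(-c5ccc(Cl)cc5)c(=O)cc4C)cc3F)ccnc2cc1OCCCN1CCN(C)CC1` differs from compound 2 at a different place: 4-chlorophenyl in place of 3-fluorophenyl on an aromatic nitrogen. Within the data shown here, no measured step touches the group on that aromatic nitrogen, so there is nothing here that tells in which direction, if any, the number should move in this assay. The expectation for compound 3 therefore rests on compound 2 alone, with a wide range to cover the unknown effect of the change. The estimated step is a 1.2-fold higher number from compound 2 to compound 3 (0.06 log units; within the scatter), no clear shift beyond the scatter. Compound 3 is thus expected to give about 300 nM, between 100 nM and 900 nM.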

Compound 3, half-maximal inhibitory concentration: 440 nM
Compound 3: middle estimate off by 1.5-fold (0.17 log units), on the low side, and the stated range covers the measured number.
By their numbers in this assay, from the lowest: compounds 2, 1 and 3 (each within the scatter of the next).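

Within the data shown here, this is the only measured change to the group on the aromatic nitrogen, and in this assay putting 4-chlorophenyl in place of 3-fluorophenyl gives a 1.7-fold higher number from compound 2 to compound 3 (0.23 log units; within the scatter) and so leaves the two compounds indistinguishable on this read-out. The position therefore accepts this exchange of one halogen-bearing phenyl ring for another without a clear shift, although the halogen and its place on the ring change together in this single step, so neither can be judged alone. No measurement shown here gives any explanation for the result.

As far as these compounds go, a 4-fluorophenyl or 3-chlorophenyl group would separate the identity of the halogen from its place on the ring, and this comparison remains open. Also open, from the compounds shown here alone, is whether a plain phenyl ring, a phenyl ring carrying an amine or a carboxylic acid, or a small alkyl group such as methyl on the same nitrogen would move the number beyond the usual scatter.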